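The compounds below may be only part of what the source reports. "The series", "measured", "known", "first", "only" and "open" are said of these compounds alone.

Measured so far:
- compound 1, `COc1ccc(NC(=O)C(=O)c2cn(C(C)C)c3c(Cl)cccc23)cn1`: 10200 nM
- compound 2, `COCCn1cc(C(=O)C(=O)Nc2ccc(C(F)(F)F)nc2)c2ccccc21`: > 10000 nM

For the measured compounds named here, in a functional assay on FaDu cells (Homo sapiens) for cytotoxicity, read by MTT assay, with a stated time of 72 h (a higher number here means that more compound is tolerated, a lower number that less compound is tolerated), compound 1 gives 10200 nM, the only plain number among the two results. For compound 2 the result of > 10000 nM is a limit of the assay, not a number, as described in the limit of > 10000 nM in this assay, at which 1 of the 2 values shown sits. Compound 3, `COc1ccc(NC(=O)C(=O)c2cn(C(C)C)c3c(OC)cccc23)cn1`, is still to be measured. It differs from compound 1 in one place: methoxy in place of chloro on an aromatic carbon. Going by the values given here, no measured step of this kind is available, so the step from compound 1 to compound 3 is expected to stay within the usual scatter, with a 1.2-fold higher number from compound 1 to compound 3 (0.07 log units; within the scatter). Compound 3 is therefore estimated at 12000 nM, within 5000 nM to 30000 nM.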

Compound 3, concentration lethal to 50% of the cells: > 10000 nM
Compound 3: no number, only a limit (the forecaster's own chance of this, stated with the estimate: 40%); the middle value does not contradict the limit.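

The result for compound 3 is a limit and not a number, so no step from compound 1 to compound 3 can be read: the limit of > 10000 nM in this assay, at which 2 of the 3 values shown sit.

The compounds shown leave open whether methoxy in place of chloro on an aromatic carbon changes the result in this assay at all.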